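Replacing the carboxy group of compound 2

The compounds below may be only part of what the source reports. "The series", "measured", "known", "first", "only" and "open" are said of these compounds alone.

In a functional assay on MCF7 cells (Homo sapiens) for cytotoxicity, read by colorimetric assay and MTT assay (on this read-out higher numbers stand for weaker inhibition and lower numbers for stronger inhibition), compound 1 `COc1ccc2cc(-c3ccccc3)c(O)nc2c1` gives 10000 nM, and compound 2 `COc1ccc(-c2cc3c(OC)cc(OC)cc3n(CC(=O)O)c2=O)cc1` stands level with it at 10000 nM. Compound 3 `CCN(CC)C(=O)CCn1c(=O)c(-c2ccc(OC)cc2)cc2c(OC)cc(OC)cc21`, not yet measured, carries (diethylcarbamoyl)methyl in place of carboxy on a saturated chain carbon bound to an aromatic nitrogen. Among the compounds with values here, no measured pair shows the effect of this change, so the only reference is compound 2 at 10000 nM. The expected step in this assay is no change at the digits printed from compound 2 to compound 3 (within the scatter), with no shift in either direction expected beyond the scatter. For compound 3 the estimated value is 10000 nM, with an expected range of 3000 nM to 20000 nM.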

Compound 3, half-maximal inhibitory concentration: 10000 nM
The estimate for compound 3 equals the measured number at the digits printed, within the range that was stated.
By their numbers in this assay, from the lowest: compounds 1, 2 and 3 (each within the scatter of the next).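

In this assay, within the data shown here, the series now has a first step at this position: (diethylcarbamoyl)methyl in place of carboxy on a saturated chain carbon bound to an aromatic nitrogen gives no change at the digits printed from compound 2 to compound 3 (within the scatter). The read-out stays level although the entering group has 0 hydrogen-bond donors against 1 for carboxy and is the larger by heavy atoms. No supporting data bear on this result.

Still open, going by these compounds, is what a primary amine or a methyl ester in this place would give in this assay. Also open, on these data alone, is whether any change to the shared core moves the read-out.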